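The compounds below may be only part of what the source reports. "The series", "measured", "known", "first", "only" and "open" are said of these compounds alone.

Compound 1 `COC(=O)c1cc(=O)c2cc(N)ccc2[nH]1`: > 33700 nM
Compound 2 `COc1ccc(-c2cc(=O)c3c(OC)cc(OC)cc3n2S(=O)(=O)c2cccc([N+](=O)[O-])c2)cc1`: > 39600 nM

Both readings come from a functional assay on HepG2 cells (Homo sapiens) for antiproliferative activity, with a stated time of 72 h (on this read-out higher numbers stand for an effect only at larger amounts of compound and lower numbers for an effect already at smaller amounts), and both are limits of the assay rather than numbers. For compound 1 the reading > 33700 nM is such a limit. For compound 2 the reading > 39600 nM is likewise a limit, as described in the limit of > 39600 nM in this assay, at which 1 of the 2 values shown sits. Compound 2 therefore shows no measurable effect within the tested range.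

Compound 3 `COc1ccc(-c2cc(=O)c3c(OC)cc(OC)cc3n2S(=O)(=O)Cc2ccccc2)cc1` has not yet been measured; it differs from compound 2 in one place: benzyl in place of 3-nitrophenyl on a sulfonyl sulfur. Among the measured compounds shown here, no step between two measured compounds is available, so the size of this change cannot be read from any comparison here. The step that the limit leaves unreadable from compound 2 to compound 3 is expected to lie within the scatter, with no direction beyond it. Compound 3 is estimated at 40000 nM, within 10000 nM to 120000 nM, and most likely reported again only as a limit.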

Compound 3, half-maximal effective concentration: > 34400 nM
Compound 3: a limit, no number (the forecaster's own chance of this, stated with the estimate: 75%); the middle value does not contradict the limit.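

Among the compounds shown here, compound 2 and compound 3 both stand only as limits in this assay, so no step between them can be read. The compounds shown leave open what amount of either would give an effect, and so whether benzyl in place of 3-nitrophenyl makes any difference.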